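From Isobutylcarbonyl to Methyl on a Nitrogen

The source may hold more compounds than are shown below. What is called first, only, known or untested is meant among the compounds shown, and "the series" means these compounds.

Of the compounds shown here, three sharing one core have been measured in an assay on CHO cells for displacement of a labelled ligand from adenosine receptor A1 (Homo sapiens), read by scintillation counting, with a stated time of 1 h, tested at 1 uM; on this read-out higher numbers stand for more inhibition at the one concentration tested (going by the name of the read-out) and lower numbers for less inhibition. Compound 1 `Nc1ncc(-c2ccc(F)cc2)c(-c2ccccc2)n1` reaches the assay's upper limit, > 80%, which is a limit rather than a number (the limit of > 80% in this assay, at which 1 of the 3 values shown sits). Compound 2 `COc1ccc(-c2cnc(N)nc2-c2ccccc2)cc1` gives 56%, a step from compound 1 of a number at least 24 percentage points lower from compound 1 to compound 2 (beyond the scatter). Compound 3 `CC(C)CC(=O)Nc1ncc(-c2cccc(Cl)c2)c(-c2ccccc2)n1` gives 56%, level with compound 2 within the scatter.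

Compound 4 `CNc1ncc(-c2cccc(Cl)c2)c(-c2ccccc2)n1` differs from compound 3 only at the group on the nitrogen: methyl in place of isobutylcarbonyl on a nitrogen on an aromatic ring. Among the compounds with values here, no measured step touches this nitrogen, so the only measured change, the one from compound 1 to compound 2, does not bear on it. Compound 4 is therefore expected to stay near compound 3, with the step of a number 1 percentage points lower from compound 3 to compound 4 (within the scatter) estimated as small and of uncertain direction. Compound 4 is estimated at 55%, in a range from 30% to 80%.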

Compound 4, a percentage reported as inhibition, at one concentration (the size of the read-out at that concentration, not a potency): 75%
For compound 4 the middle estimate is 20 percentage points below the measured one; the range from low to high includes it.
By their numbers in this assay, from the lowest: compounds 2 and 3 (each within the scatter of the next); then compound 4. At a limit, above all of these: compound 1.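

Within the data shown here, this is the first step at the nitrogen on an aromatic ring, and it shows that the group there matters in this assay. Methyl in place of isobutylcarbonyl gives a number 19 percentage points higher from compound 3 to compound 4 (beyond the scatter). Of these two groups, methyl therefore gives the greater inhibition at the one concentration tested, though this is not a measure of potency.

From the compounds shown here alone, whether the carbonyl or the length of the chain accounts for the step stays open, as does how an acetyl or ethyl group on this nitrogen would read. How far any further gain could be followed is also uncertain, since compound 1 already sits at a limit: the limit of > 80% in this assay, at which 1 of the 4 values shown sits.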